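The source may report more compounds than this note shows. Statements on the series, on what has been measured and on what is new or still open speak of the compounds shown alone.

Going by the values given here, in an ADME assay on liver (Homo sapiens) for metabolic stability, read by LC-MS, using microsomes and NADPH (a lower number here means that less of the compound is left, a higher number that more of the compound is left), compound 3 (`CCCN(Cc1ccc(OCCn2c(=O)ccn(C)c2=O)c(C)c1)C(CC(=O)O)c1ccc(Cl)cc1`) gives 30%, the lowest of the three numbers so far. Compound 2 (`CCN(Cc1ccc(OCCn2c(=O)ccn(C)c2=O)c(C)c1)C(CC(=O)O)c1ccc(Cl)cc1`) gives 46%. Compound 4 (`Cc1cc(CN(CC2CC2)C(CC(=O)O)c2ccc(Cl)cc2)ccc1OCCn1c(=O)ccn(C)c1=O`) alters compound 3 in one place: cyclopropyl in place of ethyl on a saturated chain carbon bound to an amine nitrogen, which also reads as propyl to cyclopropylmethyl. Among the compounds with values here, the only measured step on this chain is a number 16 percentage points lower from compound 2 to compound 3 (beyond the scatter), modest but beyond the scatter, with methyl in place of hydrogen. Compound 1 (`Cc1cc(CN(CC2CC2)C(CC(=O)O)c2ccc(Cl)cc2)ccc1OCCN1C(=O)CCC1=O`) also carries cyclopropylmethyl but differs elsewhere as well, so its 96% says little here. With that one modest step as the guide, only a slight upward change, within the scatter, is expected: the estimated step is a number 4 percentage points higher from compound 3 to compound 4 (within the scatter). For compound 4 the expected value is 34%, with an estimated range from 16% to 55%.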

Compound 4, percent of the compound remaining: 32%
Beside the measured number, compound 4's estimate is 2 percentage points above it, and the stated range covers the measured number.
By their numbers in this assay, from the lowest: compounds 3 and 4 (each within the scatter of the next); then compound 2; then compound 1.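

In this assay cyclopropyl in place of ethyl gives a number 2 percentage points higher from compound 3 to compound 4 (within the scatter) and so leaves the number unchanged within the scatter, which means that propyl and cyclopropylmethyl read alike at this place on the shared core. Cyclopropyl in place of methyl gives a number 14 percentage points lower from compound 2 to compound 4 (beyond the scatter) and matches the earlier drop seen with propyl. The group of 9 heavy atoms in place of the group of 7, with cyclopropylmethyl kept on the amine nitrogen, gives a number 64 percentage points lower from compound 1 to compound 4 (beyond the scatter) and is by far the largest step here. Going by these compounds, whether a longer chain such as butyl would keep the number at this level remains open. Nothing measured here explains these numbers.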